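This account rests on a few compounds, and the source may have more. Where it says the series, first, only, none or still open, it means among the compounds named here.

Values measured so far in an in vivo ADME assay on the whole organism (Macaca fascicularis) for pharmacokinetics, at a dose of 3 mg/kg by the intravenous route (on this read-out higher numbers stand for a longer-lived compound and lower numbers for a shorter-lived compound), are:

- compound 1 `N#Cc1ccc(-c2ccc(OCC(CN3C(=O)c4ccccc4C3=O)N(O)C=O)cc2)cc1` gives 0.3 h
- compound 2 `CN1C(=O)N(CC(COc2ccc(-c3ccc(C#N)cc3)cc2)N(O)C=O)C(=O)C1(C)C` gives 2.5 h
- compound 3 `N#Cc1ccc(-c2ccc(OCC(CN3C(=O)CCC3=O)N(O)C=O)cc2)cc1` gives 0.6 h

Compound 1 sits at the low end of these numbers, but not alone. Its nearest neighbour gives a 2.0-fold higher number from compound 1 to compound 3 (0.30 log units; within the scatter), so the two cannot be told apart. Its furthest neighbour gives an 8.3-fold higher number from compound 1 to compound 2 (0.92 log units; beyond the scatter).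

Compound 4 `CCN1C(=O)N(CC(COc2ccc(-c3ccc(C#N)cc3)cc2)N(O)C=O)C(=O)C1(C)C` comes from compound 1 through a single swap, (a group of 11 heavy atoms (7 carbon, 2 nitrogen, 2 oxygen; one five-membered non-aromatic ring with 2 hetero atoms) in place of a group of 11 heavy atoms (8 carbon, 1 nitrogen, 2 oxygen; one five-membered non-aromatic ring with 1 hetero atom, one six-membered aromatic ring of carbon only), on a saturated chain carbon, two bonds along the chain from an amide-type nitrogen). The entering group, 3-ethyl-4,4-dimethyl-2,5-dioxoimidazolidin-1-yl, is the closest relative of the 3,4,4-trimethyl-2,5-dioxoimidazolidin-1-yl group of compound 2. That makes the step of an 8.3-fold higher number from compound 1 to compound 2 (0.92 log units; beyond the scatter) the best guide. The step of a 4.2-fold lower number from compound 2 to compound 3 (0.62 log units; beyond the scatter) adds that 2,5-dioxopyrrolidin-1-yl does not carry the same number. Going by the values given here, no measured compound shows what ethyl in place of methyl does here, so the range must stay wide.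

Among the compounds with values here, a modest rise in this assay is therefore expected, somewhat smaller than the one seen for compound 2 with value 2.5 h. The expected change is a 7.3-fold higher number from compound 1 to compound 4 (0.87 log units; beyond the scatter). For compound 4 the estimated value is 2.2 h, with an expected range from 0.9 h to 5 h.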

Compound 4, half-life: 1.8 h
For compound 4 the middle estimate is 1.2-fold (0.09 log units) above the measured one; measured number inside the range.
By their numbers in this assay, from the lowest: compounds 1 and 3 (each within the scatter of the next); then compounds 4 and 2 (each within the scatter of the next).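

In this assay, swapping methyl for ethyl on the 2,5-dioxoimidazolidin-1-yl ring gives a 1.4-fold lower number from compound 2 to compound 4 (0.14 log units; within the scatter), so at this position the two groups cannot be told apart, and the small alkyl change seems to matter little among these two compounds. The rise from the group of compound 1 now rests on two related groups rather than one, with a 6.0-fold higher number from compound 1 to compound 4 (0.78 log units; beyond the scatter), and the entering group also stands clear of 2,5-dioxopyrrolidin-1-yl, with a 3.0-fold higher number from compound 3 to compound 4 (0.48 log units; beyond the scatter). Nothing available here explains why these groups give different half-lives.

The compounds shown do not separate the part played by the second ring nitrogen from that of the 4,4-dimethyl part of the group, as 2,5-dioxopyrrolidin-1-yl differs from the other two groups in both at once. From the compounds shown here alone, it also stays open whether a longer chain such as butyl, or a chain ending in an amine or a carboxylic acid, would hold the half-life in place of the ethyl group.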